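Removing the dimethylpyrazole: a larger step into the unknown

The compounds below may be only part of what the source reports. "The series", "measured", "known", "first", "only" and "open" are said of these compounds alone.

Of the compounds shown here, three sharing one core have been measured in an ADME assay on microsomes from liver (Mus musculus) for pharmacokinetics; on this read-out higher numbers stand for fast clearance and lower numbers for slow clearance. Compound 1 `CC(C)Oc1cc(-c2cncc(-c3cnn(C4COC4)c3)c2)ccc1C(N)=O` gives 3.1 mL.min-1.g-1, compound 2 `Cc1[nH]ncc1-c1cncc(-c2ccc(C(N)=O)c(OC(C)C)c2)c1` gives 251 mL.min-1.g-1, and compound 3 `Cc1n[nH]c(C)c1-c1cncc(-c2ccc(C(N)=O)c(OC(C)C)c2)c1` gives 62 mL.min-1.g-1. Compound 3 therefore stands second highest of the three: its nearest neighbour is compound 2, while compound 1 sits far below it.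

Compound 4 `CC(C)Oc1cc(-c2cccnc2)ccc1C(N)=O` has not been measured yet. It differs from compound 3 by hydrogen in place of 3,5-dimethyl-1H-pyrazol-4-yl on an aromatic carbon, so the whole five-membered ring is gone and only the core remains.

The measured steps all concern that same position. an 81-fold higher number from compound 1 to compound 2 (1.91 log units; beyond the scatter) and a 20-fold higher number from compound 1 to compound 3 (1.30 log units; beyond the scatter) show that swapping one pyrazole for another shifts this read-out strongly, and a 4.0-fold lower number from compound 2 to compound 3 (0.61 log units; beyond the scatter) shows that even a single methyl on the pyrazole matters. None of these steps removes the ring outright, so the direction for compound 4 rests on weaker ground. Because compound 1 gives 3.1 mL.min-1.g-1 while still carrying a pyrazole, the core itself can sit low, and the high numbers of compounds 2 and 3 appear tied to their pyrazoles. Compound 4 is therefore expected to fall, with a 3.1-fold lower number from compound 3 to compound 4 (0.49 log units; beyond the scatter), to an estimated 20 mL.min-1.g-1 in this assay, within a range of 5 mL.min-1.g-1 to 100 mL.min-1.g-1.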

Compound 4, intrinsic clearance in microsomes: 9.4 mL.min-1.g-1
The estimate for compound 4 lay 2.1-fold (0.33 log units) above the measured number; the range from low to high includes it.
By their numbers in this assay, from the lowest: compound 1; then compound 4; then compound 3; then compound 2.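

In this assay, for the compounds shown here, removing the ring outright gives a 6.6-fold lower number from compound 3 to compound 4 (0.82 log units; beyond the scatter) and a 27-fold lower number from compound 2 to compound 4 (1.43 log units; beyond the scatter), which shows for the first time that these two compounds with a pyrazole that keeps its ring hydrogen on nitrogen stand higher than the same structure with only hydrogen at this place. The same kind of removal runs the other way when 1-(oxetan-3-yl)-1H-pyrazol-4-yl is the group that leaves, with a 3.0-fold higher number from compound 1 to compound 4 (0.48 log units; beyond the scatter) on this read-out, so a pyrazole here can put the number on either side of the plain compound, and the direction of the change depends on which pyrazole is taken away. Nothing available explains why these groups differ in this way.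

The compounds shown leave open whether the low number of compound 1 belongs to the oxetan-3-yl group itself or to the pyrazole that carries it, a question that a 1-methyl-1H-pyrazol-4-yl group could help to settle. They also leave open where small groups such as a nitrile or an amine, or a six-membered ring such as phenyl, would fall at this place relative to hydrogen.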